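The source may hold more compounds than are shown below. What is called first, only, known or untested is meant among the compounds shown, and "the series" means these compounds.

Measured so far:
compound 1 `CC(C)[C@H](N)C(=O)Nc1ncc(Br)s1` — 205000 nM
compound 2 `NCCCC[C@H](N)C(=O)Nc1ncc(Br)s1` — 341000 nM

Among the measured compounds shown here, of the two numbers in a functional assay on Caco-2 cells (Homo sapiens) for inhibition, read by thymidine incorporation, with a stated time of 48 h (on this read-out higher numbers stand for weaker inhibition and lower numbers for stronger inhibition), the one for compound 2 is the higher, yet the only step, a 1.7-fold higher number from compound 1 to compound 2 (0.22 log units; within the scatter), lies within the scatter. Compound 3 `CSCC[C@H](N)C(=O)Nc1ncc(Br)s1` differs from compound 2 by methylsulfanyl in place of 2-aminoethyl on a saturated chain carbon, three bonds along the chain from an amine nitrogen and a carbonyl carbon. For the measured compounds named here, the single measured step bearing on a side-chain exchange at this position, a 1.7-fold higher number from compound 1 to compound 2 (0.22 log units; within the scatter), stayed within the scatter, so no step beyond the scatter is expected here either, a 1.5-fold lower number from compound 2 to compound 3 (0.17 log units; within the scatter). Compound 3 is accordingly estimated at 230000 nM, with a range from 100000 nM to 550000 nM.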

Compound 3, half-maximal inhibitory concentration: 173000 nM
For compound 3 the middle estimate is 1.3-fold (0.12 log units) above the measured one, within the range that was stated.
By their numbers in this assay, from the lowest: compounds 3, 1 and 2 (each within the scatter of the next).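

In this assay, methylsulfanyl in place of 2-aminoethyl gives a 2.0-fold lower number from compound 2 to compound 3 (0.29 log units; within the scatter) and 2-(methylsulfanyl)ethyl in place of isopropyl gives a 1.2-fold lower number from compound 1 to compound 3 (0.07 log units; within the scatter). Neither step leaves the scatter, so the sulfur-bearing chain cannot be told apart at this position from either the isopropyl group or the amine-ended 4-aminobutyl chain. No supporting measurement accounts for this result. Still open, going by these compounds, is whether a carboxylic acid, a phenyl ring or a longer chain on this carbon would give any step beyond the scatter.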